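The source may report more compounds than this note shows. Statements on the series, on what has been measured and on what is new or still open speak of the compounds shown alone.

Measured compounds:
compound 1 `COc1ccccc1N1CCN(CCC(Oc2ccc(NC(=O)c3ccccc3OCCCC(=O)O)cc2)c2ccc(C)cc2)CC1` 79.4 nM
compound 2 `CCc1ccc(C(CCN2CCN(c3ccccc3OC)CC2)Oc2ccc(NC(=O)c3ccccc3OCCCC(=O)O)cc2)cc1` 200 nM
compound 3 `COc1ccccc1N1CCN(CCC(Oc2ccc(C(=O)Nc3ccccc3OCCCC(=O)O)cc2)c2ccccc2)CC1` 25.1 nM

All three values come from an assay on Prostate gland (Oryctolagus cuniculus) for inhibition of Adrenergic receptor alpha-1 (Homo sapiens); on this read-out lower numbers stand for tighter binding and higher numbers for weaker binding. Compound 3 gives the lowest number of the three: compound 1 sits well above it and compound 2 further still, and both gaps are beyond the scatter. Among the measured compounds shown here, compound 3 differs from compounds 1 and 2 in more than one place, so no single step to it is given; only its value can be set beside theirs.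

Compound 4 `CCc1ccc(C(CCN2CCN(c3ccccc3OC)CC2)Oc2ccc(C(=O)Nc3ccccc3OCCCC(=O)O)cc2)cc1` differs from compound 3 by ethyl in place of hydrogen on an aromatic carbon. For the measured compounds named here, no measured step matches this change exactly. The nearest is a 2.5-fold higher number from compound 1 to compound 2 (0.40 log units; beyond the scatter), which lengthened methyl to ethyl on the ring that carries this group in the shared core and moved the number up modestly. Taking that as a guide, the larger change from hydrogen to ethyl is expected to move the number up somewhat more, estimated as a 3.2-fold higher number from compound 3 to compound 4 (0.50 log units; beyond the scatter). Compound 4 is therefore expected to give 80 nM in this assay, within 30 nM to 250 nM.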

Compound 4, dissociation constant: 39.8 nM
Beside the measured number, compound 4's estimate is 2.0-fold (0.30 log units) above it; low and high end bracket the measured number.
By their numbers in this assay, from the lowest: compounds 3, 4 and 1 (each within the scatter of the next, the first and the last beyond it); then compound 2.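

In this assay the change from phenyl to 4-ethylphenyl gives a 1.6-fold higher number from compound 3 to compound 4 (0.20 log units; within the scatter) and so leaves compounds 3 and 4 indistinguishable. Among the compounds shown here, this is the first direct reading of hydrogen against ethyl on this aromatic carbon, and it shows that this position accepts ethyl of compound 3, whereas the only earlier step at this position, a 2.5-fold higher number from compound 1 to compound 2 (0.40 log units; beyond the scatter), was methyl to ethyl with the amide of the shared core turned the other way. No available evidence bears on the reason for this result.

As far as these compounds go, whether methyl, methoxy, chlorine or a longer chain such as butyl would also be accepted at this carbon remains open. Also open, from the compounds shown here alone, is how hydrogen at this position would compare with methyl and ethyl when the amide is oriented as in compounds 1 and 2.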